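Hydroxy for methoxy on the amine side chain

A few compounds are considered here, and "the series" means these few. Any claim that something is new, unique, unknown or untested is made for them only; others in the source may bear on it.

Measured so far in an ADME assay on CHO-K1 cells (Cricetulus griseus) for activation, read by fluorescence, tested at 10 uM; on this read-out lower numbers stand for a stronger effect and higher numbers for a weaker effect at the one concentration tested:
compound 1 `O=C(/C=C(/C=C/c1ccc(O)cc1)NCCCO)/C=C/c1ccc(O)cc1`: 80.5%
compound 2 `COc1cc(/C=C/C(=O)/C=C(/C=C/c2ccc(O)c(OC)c2)NCCCO)ccc1O`: 89.9%
compound 3 `COCCNC(=C\C(=O)/C=C/c1ccc(O)cc1)/C=C/c1ccc(O)cc1`: 75.1%

Compound 3 stands lowest of the three numbers; the nearest is compound 1, within the scatter, and the furthest is compound 2, beyond it. Compound 4 `O=C(/C=C(/C=C/c1ccc(O)cc1)NCCO)/C=C/c1ccc(O)cc1` differs from compound 3 by hydrogen in place of methyl on an oxygen on a saturated carbon. Going by the values given here, the one step that bears on this is a number 5.4 percentage points lower from compound 1 to compound 3 (within the scatter), where methoxy replaced hydroxymethyl on a saturated chain carbon two bonds along the chain from an amine nitrogen and the number stayed within the scatter. Returning to a hydroxy is therefore expected to move little: the expected step is a number 4.9 percentage points higher from compound 3 to compound 4 (within the scatter), nothing beyond the scatter. For compound 4 the estimate is 80%, with a range from 68% to 92%.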

Compound 4, a percentage reported as activity, at one concentration (the size of the read-out at that concentration, not a potency): 85.7%
Compound 4: the middle estimate sits 5.7 percentage points below what was measured; low and high end bracket the measured number.
By their numbers in this assay, from the lowest: compounds 3, 1, 4 and 2 (each within the scatter of the next, the first and the last beyond it).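

In this assay, hydrogen in place of methyl on the oxygen of the side chain gives a number 10.6 percentage points higher from compound 3 to compound 4 (beyond the scatter) and is the only step on the amine side chain shown here to lie beyond the scatter. Hydroxy in place of hydroxymethyl gives a number 5.2 percentage points higher from compound 1 to compound 4 (within the scatter) and stays within it, so compound 1 sits within the scatter of both compound 3 and compound 4, while those two separate. On these data alone, how an amine or a carboxylic acid at the end of this chain would read remains open. Nothing measured here accounts for the step.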